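From nitrophenyl to pyridyl on the amide carbonyl

The source may hold more compounds than are shown below. What is called first, only, known or untested is meant among the compounds shown, and "the series" means these compounds.

Compound 1 `COc1cccc(C(=O)Nc2ccc(Cl)cc2CN2C(=O)c3ccccc3C2=O)c1` and compound 2 `O=C(Nc1ccc(Cl)cc1CN1C(=O)c2ccccc2C1=O)c1ccccc1[N+](=O)[O-]` share the same core and differ only in the aryl group attached to the amide carbonyl. In an assay on CHO cells for positive allosteric modulation of metabotropic glutamate receptor 5 (Rattus norvegicus), read by FLIPR (a higher number here means that more compound is needed for the effect, a lower number that less compound is needed), compound 1 reaches only a limit of the assay, < 1000 nM. In this assay compound 2 likewise reaches only a limit, < 1000 nM. The step that the two limits leave unreadable from compound 1 to compound 2 cannot be sized, since both ends sit at the same limit (the limit of < 1000 nM in this assay, at which 2 of the 2 values shown sit). Compound 3 `O=C(Nc1ccc(Cl)cc1CN1C(=O)c2ccccc2C1=O)c1cccnc1` has not yet been measured; it differs from compound 2 by pyridin-3-yl in place of 2-nitrophenyl on a carbonyl carbon. For the measured compounds named here, no measured step gives a readable size for a change of this kind, so no shift beyond the usual scatter is foreseen, and the limit at which compound 2 sits is the only anchor. For compound 3 the value in this assay is expected to be 300 nM, within a range from 60 nM to 1500 nM. The step that the limit leaves unreadable from compound 2 to compound 3 that this estimate implies is expected to stay within the scatter.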

Compound 3, half-maximal effective concentration: < 1000 nM
Compound 3 was reported as a limit; the forecaster's own chance of this, stated with the estimate: 40%; the middle value lies beyond the limit too.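

For the compounds shown here, no step among compound 1, compound 2 and compound 3 can be sized in this assay, because each compound is reported only as a limit: the limit of < 1000 nM in this assay, at which 3 of the 3 values shown sit.

The compounds shown leave open whether 3-methoxyphenyl, 2-nitrophenyl and pyridin-3-yl differ at all in the concentration needed for the effect.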